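The compounds below may be only part of what the source reports. "The series", "measured", "known", "first", "only" and "open" are said of these compounds alone.

Among the measured compounds shown here, in a functional assay on SK-BR-3 cells (Homo sapiens) for inhibition, read by MTT assay (a higher number here means a weaker inhibitor of growth, a lower number a stronger inhibitor of growth), compound 3 `CC1=C(/C=C/C(C)=C/C=C/C(C)=C\C(=O)NCc2ccc(O)cc2)C(C)(C)CCC1n1ccnc1` gives 2450 nM and compound 1 `CC1=C(/C=C/C(C)=C/C=C/C(C)=C\C(=O)Nc2ccc(O)cc2)C(C)(C)CCC1n1ccnc1` gives 3890 nM, which places them level at the low end of the numbers so far. The gap between them is small: a 1.6-fold lower number from compound 1 to compound 3 (0.20 log units; within the scatter). Compound 2 `CC1=C(/C=C/C(C)=C/C=C/C(C)=C\C(=O)Nc2cccc(F)c2)C(C)(C)CCC1n1ccnc1` gives 17000 nM, and its contrast with compound 3 is larger: a 6.9-fold lower number from compound 2 to compound 3 (0.84 log units; beyond the scatter).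

The next compound, compound 4 `CC1=C(/C=C/C(C)=C/C=C/C(C)=C\C(=O)Nc2ccccc2O)C(C)(C)CCC1n1ccnc1`, has 2-hydroxyphenyl in place of 4-hydroxybenzyl on an amide-type nitrogen. Its closest measured relative, since it also carries a hydroxyphenyl group, is compound 1, and compound 1 gives 3890 nM. For the measured compounds named here, no measured compound carries 2-hydroxyphenyl, however, and swapping the group on a phenyl ring can matter, as a 4.4-fold higher number from compound 1 to compound 2 (0.64 log units; beyond the scatter) shows. The range should therefore stretch further towards higher numbers.

In this assay, the estimated step is a 1.8-fold higher number from compound 3 to compound 4 (0.26 log units; within the scatter), an expected small rise that stays within the scatter. The expected value for compound 4 is 4500 nM, with an estimated range of 1800 nM to 12000 nM.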

Compound 4, concentration for 50% growth inhibition: 3890 nM
Compound 4: the middle estimate sits 1.2-fold (0.06 log units) above what was measured; the range from low to high includes it.
By their numbers in this assay, from the lowest: compounds 3, 1 and 4 (each within the scatter of the next); then compound 2.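

In this assay, 2-hydroxyphenyl on the amide-type nitrogen stands level with 4-hydroxyphenyl, with no change at the digits printed from compound 1 to compound 4 (within the scatter), and also with 4-hydroxybenzyl, with a 1.6-fold higher number from compound 3 to compound 4 (0.20 log units; within the scatter). Against 3-fluorophenyl the new group shows a clear gap, with a 4.4-fold lower number from compound 2 to compound 4 (0.64 log units; beyond the scatter), so the three compounds carrying a hydroxyl group now sit together and compound 2 alone stands apart. Nothing available gives a reason for this grouping.

Whether the gap belongs to the fluorine itself or to where it sits on the ring stays open: the compounds shown include no 3-hydroxyphenyl, 2-fluorophenyl or 4-fluorophenyl. A plain phenyl, or a phenyl carrying an amine or a carboxylic acid, would also show whether the hydroxyl group is needed at all.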